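The source may hold more compounds than are shown below. What is called first, only, known or untested is meant among the compounds shown, and "the series" means these compounds.

Within the data shown here, in a functional assay on a cell-free system (plasma, Oryctolagus cuniculus) for inhibition, with stated times of 5 min, 1 min and 6 min (a lower number here means a stronger inhibitor, a higher number a weaker inhibitor), two compounds on one shared core have numbers so far. Compound 1, `CCOC(=O)c1c(C)nc(-c2cccc(C#N)c2)n1OC`, gives 9130 nM. Compound 2, `CCOC(=O)c1c(C)nc(-c2cccc(C#N)c2)n1OCc1cccc(Cl)c1`, gives 19400 nM, the higher of the two numbers and so the weaker inhibitor. Compound 3, `CCOC(=O)c1c(C)nc(-c2cccc(C#N)c2)n1OCc1ccc(Cl)cc1`, has 4-chlorophenyl in place of 3-chlorophenyl on a saturated chain carbon bound to an oxygen on an aromatic ring. Among the measured compounds shown here, only one measured step bears on this change, a 2.1-fold higher number from compound 1 to compound 2 (0.33 log units; beyond the scatter), which brought in the 3-chlorophenyl group and was modest. For the measured compounds named here, no measured compound carries 4-chlorophenyl, so the data do not show what this swap does. Going by the values given here, with only that modest step as a guide, no shift beyond the scatter is expected in this assay. The estimated step is a 1.1-fold lower number from compound 2 to compound 3 (0.03 log units; within the scatter). For compound 3 the expected value is 18000 nM, with an estimated range of 8000 nM to 40000 nM.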

Compound 3, half-maximal inhibitory concentration: 6830 nM
Estimate against measurement, compound 3: 2.6-fold (0.42 log units) above; the measured number lies below the stated range.
By their numbers in this assay, from the lowest: compounds 3 and 1 (each within the scatter of the next); then compound 2.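

Swapping 3-chlorobenzyl for 4-chlorobenzyl keeps the same atoms, yet in this assay it gives a 2.8-fold lower number from compound 2 to compound 3 (0.45 log units; beyond the scatter), so the place of the chlorine on this ring changes the result. Set against hydrogen on the chain carbon, 4-chlorophenyl gives a 1.3-fold lower number from compound 1 to compound 3 (0.13 log units; within the scatter), so this position takes the 4-chlorobenzyl group with no shift beyond the scatter, whereas the 3-chlorobenzyl group raised the number. Nothing available explains why the two chlorine placements differ.

The compounds shown leave open what a plain benzyl group would give, and whether a fluorine or a methoxy group in place of the chlorine would follow the same pattern. They also leave open whether a longer chain between the oxygen and the ring, or an amide in place of the ethyl ester, would preserve this difference.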